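Working notes: cytotoxicity across three measured amide analogues

The source may report more compounds than this note shows. Statements on the series, on what has been measured and on what is new or still open speak of the compounds shown alone.

Measured so far in an ADME assay on HEK293 cells (Homo sapiens) for cytotoxicity, read by MTT assay, with a stated time of 72 h; a higher number here means a weaker inhibitor, a lower number a stronger inhibitor:
compound 1 `COc1ccc2[nH]cc(CCCN3CCN(C(=O)CN4CCN(C(=O)c5ccc(Cl)cc5)CC4)CC3)c2c1` gives 117000 nM
compound 2 `COc1ccc(C(=O)N2CCN(CC(=O)N3CCN(CCCc4c[nH]c5ccc(OC)cc45)CC3)CC2)cc1` gives 190000 nM
compound 3 `COc1ccc2[nH]cc(CCCN3CCN(C(=O)CN4CCN(C(=O)c5cccc(Cl)c5)CC4)CC3)c2c1` gives 143000 nM

All three numbers in this assay sit close together, and every step among them is within the scatter of repeated measurements. The difference between compound 1 and compound 3 is 3-chlorophenyl in place of 4-chlorophenyl on a carbonyl carbon, and the step is a 1.2-fold higher number from compound 1 to compound 3 (0.09 log units; within the scatter). The difference between compound 2 and compound 3 is a 1.3-fold lower number from compound 2 to compound 3 (0.12 log units; within the scatter).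

Compound 4 `COc1cccc(C(=O)N2CCN(CC(=O)N3CCN(CCCc4c[nH]c5ccc(OC)cc45)CC3)CC2)c1` is not yet measured. It differs from compound 3 by methoxy in place of chloro on an aromatic carbon. The same change has already been made once, from compound 1 to compound 2, where it reads methoxy in place of chloro on an aromatic carbon and gave a 1.6-fold higher number from compound 1 to compound 2 (0.21 log units; within the scatter). The two places are not the same word for word: in compound 1 the group sits para to a large group, in compound 3 meta to a large group, so the change from compound 3 to compound 4 is the same kind of change, not the same one.

For compound 4 the expected step in this assay is a 1.4-fold higher number from compound 3 to compound 4 (0.15 log units; within the scatter), resting on the earlier step of a 1.6-fold higher number from compound 1 to compound 2 (0.21 log units; within the scatter), which itself stayed within the scatter. Compound 4 is therefore estimated at 200000 nM, with a range from 100000 nM to 400000 nM.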

Compound 4, half-maximal inhibitory concentration: > 200000 nM
Compound 4 ended at the assay's limit (the forecaster's own chance of this, stated with the estimate: 25%); the middle value lies on the limit itself.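

In this assay compound 4 gives > 200000 nM and that is a limit of the assay, not a number: the limit of > 200000 nM in this assay, at which 1 of the 4 values shown sits.

Methoxy in place of chloro on an aromatic carbon, here meta to a large group, gives an at least 1.3-fold higher number from compound 3 to compound 4 (0.14 log units; that floor lies within the scatter) and the two other new steps, an at least 1.0-fold higher number from compound 2 to compound 4 (0.02 log units; that floor lies within the scatter) and an at least 1.7-fold higher number from compound 1 to compound 4 (0.23 log units; that floor lies within the scatter), can likewise be read only as floors. The change can thus be followed on the second core only as far as that floor, which shows no conflict between the two cores but does not show that the step carries over unchanged or that it differs: the same change on two cores in this assay, a 1.6-fold higher number (0.21 log units; within the scatter) from compound 1 to compound 2 and an at least 1.3-fold higher number (0.14 log units; that floor lies within the scatter) from compound 3 to compound 4; the limit leaves it open whether they differ.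

The compounds shown carry only chloro and methoxy on the phenyl group of the carbonyl, so it remains open how an amine or a carboxylic acid at that place would read in this assay and whether any such compound would give a value clear of the limit. Also open, as far as these compounds go, is whether a longer chain in place of the one shared by all four compounds would move the read-out beyond the scatter.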